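Chloro in place of hydrogen on compound 1

A few compounds are considered here, and "the series" means these few. Any claim that something is new, unique, unknown or untested is made for them only; others in the source may bear on it.

For the measured compounds named here, in a functional assay on A549 cells (Homo sapiens) for cytotoxicity, read by sulforhodamine B assay, with a stated time of 96 h (on this read-out higher numbers stand for an effect only at larger amounts of compound and lower numbers for an effect already at smaller amounts), compound 1 `CCCC(=O)CC/C=C/C=C/C#CC#C/C=C/COC(C)=O` gives 56400 nM, the highest of the two numbers so far. Going by the values given here, the only other measured compound, compound 2 `CCCC(=O)CC/C=C/C=C/C#CC#C/C=C/COC(=O)c1ccccc1`, gives 14400 nM.

The open case is compound 3 `CCCC(=O)CC/C=C/C=C/C#CC#C/C=C/COC(=O)CCl`. Its difference from compound 1 is chloro in place of hydrogen on a saturated chain carbon bound to a carbonyl carbon, which also reads as methyl to chloromethyl.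

Among the compounds with values here, one measured step bears on this change: a 3.9-fold lower number from compound 1 to compound 2 (0.59 log units; beyond the scatter). That step is modest and beyond the scatter, and it puts phenyl in place of the same methyl on a carbonyl carbon. Within the data shown here, no measured compound carries chloro, so this single step offers only a rough guide to direction and size.

A lower number in this assay is therefore expected, with a step somewhat smaller than the phenyl one. The estimated change is a 2.3-fold lower number from compound 1 to compound 3 (0.35 log units; beyond the scatter), and the wide range allows for no real change at all. For compound 3 the expected value is 25000 nM, with an estimated range of 8000 nM to 65000 nM.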

Compound 3, half-maximal effective concentration: 5100 nM
Estimate against measurement, compound 3: 4.9-fold (0.69 log units) above, outside the stated range (below it).
By their numbers in this assay, from the lowest: compound 3; then compound 2; then compound 1.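

In this assay, chloro in place of hydrogen on a saturated chain carbon bound to a carbonyl carbon gives an 11-fold lower number from compound 1 to compound 3 (1.04 log units; beyond the scatter), so this position responds strongly to a change of a single heavy atom, which the phenyl step alone could not show. Chloromethyl on the carbonyl carbon also goes further than phenyl, with a 2.8-fold lower number from compound 2 to compound 3 (0.45 log units; beyond the scatter), so among these three compounds the number does not follow the size of the entering group: the single chlorine outdoes the whole ring, and compound 3 now holds the lowest number in the series. No measurement shown here accounts for the size of this drop, and the series offers only these three numbers on which to judge it.

As far as these compounds go, whether the step belongs to chlorine itself stays open, since fluoro, bromo or a dimethylamino group on the same saturated chain carbon would be needed to separate chloro from other replacements of hydrogen. A longer chain carrying the chloro, and a dichloromethyl group in place of chloromethyl, would show how far the effect extends at this position.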